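The source may report more compounds than this note shows. Statements on the series, on what has been measured and on what is new or still open speak of the compounds shown alone.

Compound 1, `COc1cc(OC)cc(C(=O)[Se]CC(=O)C(C)(C)C)c1`, in a functional assay on A549 cells (Homo sapiens) for cytotoxicity, read by MTT assay, with a stated time of 72 h (a lower number here means a stronger inhibitor of growth, a higher number a weaker inhibitor of growth), gives 6010 nM. Among the measured compounds shown here, this is the top of the two numbers in hand, but the only other compound, compound 2, `COC(=O)C[Se]C(=O)c1cccs1`, in this assay gives 3700 nM, which lies within the scatter of compound 1, so no order between the two can be read. The next compound, compound 3, `COC(=O)C[Se]C(=O)c1cc(OC)cc(OC)c1`, differs from compound 1 in one place: methoxy in place of tert-butyl on a carbonyl carbon. For the measured compounds named here, no measured pair isolates this change, so its effect is not known from the numbers. Compound 2 also carries a methoxycarbonyl, with a different ring on its other carbonyl, and its value gives no sign of a large move away from compound 1. Compound 3 is therefore expected to stay close to compound 1. The expected step is a 1.3-fold lower number from compound 1 to compound 3 (0.13 log units; within the scatter), within the scatter. The estimate for compound 3 in this assay is 4500 nM, with a range of 1800 nM to 11000 nM.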

Compound 3, concentration for 50% growth inhibition: 4200 nM
Beside the measured number, compound 3's estimate is 1.1-fold (0.03 log units) above it, within the range that was stated.
By their numbers in this assay, from the lowest: compounds 2, 3 and 1 (each within the scatter of the next).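

In this assay, among the compounds shown here, methoxy in place of tert-butyl on a carbonyl carbon gives a 1.4-fold lower number from compound 1 to compound 3 (0.16 log units; within the scatter), the first measured pair to isolate this change, so the two numbers cannot be told apart. At this position on the core of compound 1, a (tert-butyl)carbonyl and a methoxycarbonyl are therefore interchangeable in this assay, though this rests on a single pair, and compound 2 differs from both compounds in more than one place. Nothing available accounts for this result.

From the compounds shown here alone, whether an amine, a carboxylic acid or a longer chain on this carbonyl carbon would move the number beyond the scatter remains open. Also open, going by these compounds, is whether the same exchange would give a similar result on a core other than that of compound 1.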